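Heptyloxy to methyl in a small cytotoxicity series

This account rests on a few compounds, and the source may have more. Where it says the series, first, only, none or still open, it means among the compounds named here.

Measured so far in a functional assay on HL-60 cells (Homo sapiens) for cytotoxicity, read by WST assay, with a stated time of 48 h; on this read-out lower numbers stand for an effect already at smaller amounts and higher numbers for an effect only at larger amounts of compound:
Compound 1 `O=C1OC[C@H](Cc2ccccc2)[C@H]1Cc1ccccc1Cl` gives 37000 nM.
Compound 2 `CCCCCCCOc1cccc(C[C@H]2C(=O)OC[C@@H]2Cc2ccccc2)c1` gives 81000 nM.

Of these two numbers, the higher belongs to compound 2 at 81000 nM and its gap to compound 1 lies beyond the usual scatter. With only these two compounds, no trend can be claimed.

Compound 3 `Cc1cccc(C[C@H]2C(=O)OC[C@@H]2Cc2ccccc2)c1` is the next case. It differs from compound 2 by methyl in place of heptyloxy on an aromatic carbon, meta to a large group, and the counted difference is methyl in place of heptyloxy on an aromatic carbon here. Among the compounds with values here, no measured pair differs in one place only, so this change has no direct precedent in this assay and the expectation rests on thin evidence. A modest move toward a lower number is expected, near the edge of the scatter, since compound 1 gives 37000 nM without any heptyloxy. The estimated change is a 1.9-fold lower number from compound 2 to compound 3 (0.29 log units; within the scatter) and its size remains uncertain. For compound 3 the expected value is 42000 nM with an estimated range from 15000 nM to 100000 nM.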

Compound 3, half-maximal effective concentration: 53000 nM
Beside the measured number, compound 3's estimate is 1.3-fold (0.10 log units) below it; the measured number falls inside the stated range.
By their numbers in this assay, from the lowest: compounds 1, 3 and 2 (each within the scatter of the next, the first and the last beyond it).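

In this assay, within the data shown here, methyl in place of heptyloxy on an aromatic carbon, meta to a large group, gives a 1.5-fold lower number from compound 2 to compound 3 (0.18 log units; within the scatter) and provides the first direct reading at this position. Shortening the substituent from the heptyloxy chain to a single methyl therefore produces no change beyond the usual scatter, so this pair gives no sign that the heptyloxy chain matters for the read-out. The second comparison, 3-methylphenyl in place of 2-chlorophenyl on a saturated chain carbon bound to a saturated ring carbon, gives a 1.4-fold higher number from compound 1 to compound 3 (0.16 log units; within the scatter) and also stays within the scatter, while nothing available explains the size of either step.

On these data alone, with only methyl and heptyloxy read at this position, it remains open whether a group of another kind there, such as an amine or a carboxylic acid, would shift the number beyond the scatter. As far as these compounds go, it also remains open whether an intermediate chain such as butoxy would behave like either of these two groups, and whether chlorine at this same position would give a number distinct from that of methyl.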